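Adding a 4-(methoxycarbonyl)benzyl group: tolerated concentration

The source may hold more compounds than are shown below. What is called first, only, known or untested is meant among the compounds shown, and "the series" means these compounds.

Compound 3 `Cc1cc(=O)oc2cc(OCC(O)CN3CCC(C(N)=O)CC3)ccc12` was read in an ADME assay on A549 cells (Homo sapiens) for cytotoxicity, read by CellTiter-Glo; a higher number here means that more compound is tolerated, a lower number that less compound is tolerated. In this assay compound 3 gives > 100000 nM, a limit of the assay and not a number. Compound 1 `Cc1c(Cc2ccccc2)c(=O)oc2cc(OCC(O)CNc3ccccc3)ccc12` sits at the same limit: in this assay compound 1 gives > 100000 nM. Compound 2 `Cc1c(Cc2ccccc2)c(=O)oc2cc(OCC(O)CNc3ccc(Br)cc3)ccc12` likewise: in this assay compound 2 gives > 100000 nM. The step that the two limits leave unreadable from compound 1 to compound 2 is thus unreadable, and compound 3 cannot be placed against the other two; all three sit at the limit of > 100000 nM in this assay, at which 3 of the 3 values shown sit. Compound 4 `COC(=O)c1ccc(Cc2c(C)c3ccc(OCC(O)CN4CCC(C(N)=O)CC4)cc3oc2=O)cc1` differs from compound 3 by 4-(methoxycarbonyl)benzyl in place of hydrogen on an aromatic carbon. Among the compounds with values here, the only measured step concerns another position and is unreadable, so no step beyond the scatter is expected in either direction. The expected step of a number no higher from compound 3 to compound 4 (the limit leaves the size open) is nil. Compound 4 is expected at 100000 nM, within 50000 nM to 200000 nM.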

Compound 4, half-maximal cytotoxic concentration: > 100000 nM
Compound 4: no number, only a limit; the forecaster's own chance of this, stated with the estimate: 85%; the middle value lies on the limit itself.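

Within the data shown here, compound 4, like compound 3, sits at a limit of this assay and not at a number, so no step between them can be read: the limit of > 100000 nM in this assay, at which 4 of the 4 values shown sit.
As far as these compounds go, whether 4-(methoxycarbonyl)benzyl in place of hydrogen changes the tolerated concentration at all stays open.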